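Swapping the Aryl Group on a Shared Core

The source may hold more compounds than are shown below. What is called first, only, known or untested is meant among the compounds shown, and "the series" means these compounds.

Compound 2 `CCc1ccc(NC2=CC(=O)c3c(nc4n3[C@H]3OC[C@@H](O)[C@H]3OC4)C2=O)cc1` and compound 1 `CCCc1ccc(NC2=CC(=O)c3nc4n(c3C2=O)[C@H]2OC[C@@H](O)[C@H]2OC4)cc1` share one core and differ only in the group carried on the amine nitrogen. In a functional assay on MGC-803 cells (Homo sapiens) for inhibition, read by sulforhodamine B assay (on this read-out higher numbers stand for weaker inhibition and lower numbers for stronger inhibition), compound 2 gives 1110 nM, while compound 1 gives 1560 nM; the gap between these two numbers lies within the usual scatter of repeated measurements, so neither compound can be called the stronger inhibitor. Compound 3 `O=C1C(Nc2cccc(F)c2)=CC(=O)c2c1nc1n2[C@H]2OC[C@@H](O)[C@H]2OC1` has not yet been measured. It differs from compound 2 in one place: 3-fluorophenyl in place of 4-ethylphenyl on an amine nitrogen. For the measured compounds named here, nothing among the measured compounds shows how such a change acts on the read-out, since the only measured pair differs elsewhere and sits within the scatter. The step from compound 2 to compound 3 is therefore expected to be small, a 1.4-fold higher number from compound 2 to compound 3 (0.13 log units; within the scatter), and not beyond the scatter. Compound 3 is estimated at 1500 nM in this assay, with a range from 500 nM to 4500 nM.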

Compound 3, half-maximal inhibitory concentration: 1470 nM
For compound 3 the middle estimate is 1.0-fold (0.01 log units) above the measured one; low and high end bracket the measured number.
By their numbers in this assay, from the lowest: compounds 2, 3 and 1 (each within the scatter of the next).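

This is the first step among these compounds with a single, readable change at this position. In this assay, 3-fluorophenyl in place of 4-ethylphenyl on the amine nitrogen gives a 1.3-fold higher number from compound 2 to compound 3 (0.12 log units; within the scatter), so the two aryl groups cannot be told apart on this read-out, although they carry different substituents on the ring. Nothing measured here explains why they read alike.

On these data alone, what remains open is whether this position stays as undemanding with a group of another kind on the ring, such as a carboxylic acid or an amine. As far as these compounds go, it is equally open whether replacing the phenyl ring itself, for instance with a plain alkyl chain on the amine nitrogen, would move the number beyond the scatter.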